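This account rests on a few compounds, and the source may have more. Where it says the series, first, only, none or still open, it means among the compounds named here.

Working notes on the series. Among the compounds with values here, the shared core carries an isopropyl on a ring nitrogen and an amide-linked aryl group; the two measured members differ in both the amide substituent and the group on the other ring position. Compound 1 `CC(C)n1ncc2c(C(=O)Nc3ccccn3)cc(C3CC3)nc21` carries a cyclopropyl and a pyridin-2-yl amide; in an ADME assay on LLC-MK2 cells (Macaca mulatta) for cytotoxicity, read by spectrophotometry and crystal violet staining, with a stated time of 4 days (on this read-out lower numbers stand for higher toxicity in this test and higher numbers for lower toxicity in this test), compound 1 gives 25000 nM. Compound 2 `CC(C)n1ncc2c(C(=O)Nc3ccncc3)cc(-c3cccs3)nc21` carries a thiophen-2-yl and a pyridin-4-yl amide; in this assay compound 2 gives 6300 nM, the lowest of the two numbers, with compound 1 standing higher by a margin beyond the scatter.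

Compound 3 `CC(C)n1ncc2c(C(=O)Nc3cccc(S(N)(=O)=O)c3)cc(-c3cccs3)nc21` keeps the thiophen-2-yl and changes the amide substituent: 3-sulfamoylphenyl in place of pyridin-4-yl on an amide-type nitrogen. Within the data shown here, no measured pair in the set carries this change, so its size has no direct precedent. The expectation is for a step from compound 2 to compound 3 in this assay of a 1.6-fold higher number from compound 2 to compound 3 (0.20 log units; within the scatter), a modest rise that may not clear the scatter. Compound 3 is accordingly estimated at 10000 nM, within a range of 3000 nM to 40000 nM.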

Compound 3, half-maximal cytotoxic concentration: 25000 nM
The estimate for compound 3 lay 2.5-fold (0.40 log units) below the measured number; the measured number falls inside the stated range.
By their numbers in this assay, from the lowest: compound 2; then compounds 1 and 3 (each within the scatter of the next).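

Within the data shown here, with the thiophen-2-yl held fixed, compound 2 and compound 3 give the first comparison that differs in one place, and in this assay the amide substituent alone gives a 4.0-fold higher number from compound 2 to compound 3 (0.60 log units; beyond the scatter). The substituent on the amide-type nitrogen therefore has a readable effect on this read-out, and here the change from pyridin-4-yl to the larger 3-sulfamoylphenyl goes with lower toxicity in this test, a modest step but one beyond the scatter. The data shown include no measurement that accounts for this step, so its origin remains unassigned.

From the compounds shown here alone, the step replaces the ring and adds the sulfamoyl group together, so it remains open how much of the rise belongs to the loss of the pyridine ring nitrogen and how much to the sulfamoyl group, a question that plain phenyl would help to separate, as would a phenyl carrying a carboxylic acid or an amine in place of the sulfamoyl. Compound 1 differs from compound 2 and from compound 3 in two places, which leaves the separate contribution of the cyclopropyl and the thiophen-2-yl unresolved.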